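A few compounds are considered here, and "the series" means these few. Any claim that something is new, unique, unknown or untested is made for them only; others in the source may bear on it.

In an ADME assay on cells (Hepatocyte, Rattus norvegicus, strain Wistar) for pharmacokinetics, read by LC-MS, with a stated time of 90 min, tested at 1 uM (on this read-out lower numbers stand for slow clearance and higher numbers for fast clearance), compound 1 `COc1cc(C(=O)N2CCCC2(C)C)cc2nc(NCc3cccc(Cl)c3)oc12` gives 58.3 mL/min/kg and compound 2 `COc1cc(C(=O)N2CC(C)C(O)CC2C)cc2nc(NCc3cccc(Cl)c3)oc12` gives 56.7 mL/min/kg on the same read-out, so the two stand level within the usual scatter. Compound 3 `COc1cc(C(=O)N2CC(C)C(O)CC2C2CC2)cc2nc(NCc3cccc(Cl)c3)oc12` has cyclopropyl in place of methyl on a saturated ring carbon, next to the ring nitrogen (cyclopropyl in place of methyl on a saturated ring carbon). Going by the values given here, the one measured step (a 1.0-fold lower number from compound 1 to compound 2 (0.01 log units; within the scatter)) replaced the whole group on the carbonyl carbon, putting 4-hydroxy-2,5-dimethylpiperidin-1-yl in place of 2,2-dimethylpyrrolidin-1-yl, and it stayed within the scatter. Among the compounds with values here, no measured compound carries a cyclopropyl, so that step is only indirect evidence. The expected step is small (a 1.0-fold lower number from compound 2 to compound 3 (0.01 log units; within the scatter)), with no move beyond the scatter in either direction in this assay on this evidence. Compound 3 is estimated at 56 mL/min/kg (expected range 33 mL/min/kg to 92 mL/min/kg).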

Compound 3, clearance: 63.3 mL/min/kg
Beside the measured number, compound 3's estimate is 1.1-fold (0.05 log units) below it; the range from low to high includes it.
By their numbers in this assay, from the lowest: compounds 2, 1 and 3 (each within the scatter of the next).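

In this assay, putting cyclopropyl in place of methyl on a saturated ring carbon, next to the ring nitrogen, gives a 1.1-fold higher number from compound 2 to compound 3 (0.05 log units; within the scatter) and so stays within the usual scatter. This position therefore takes a three-membered ring of carbon without a clear shift in clearance, which the earlier pair could not show because neither compound carries that ring. Exchanging the whole group on the carbonyl carbon gives a 1.1-fold higher number from compound 1 to compound 3 (0.04 log units; within the scatter) and is also within the scatter, leaving all three compounds level, and no measurement at hand offers an explanation for this.

Going by these compounds, what an aminomethyl group or a tert-butyl group on the same ring carbon would do remains open. So does whether cyclopropyl would behave the same way without the hydroxy group two ring bonds away.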